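Carbamoylmethyl for methoxycarbonyl on the chain of compound 3

The source may report more compounds than this note shows. Statements on the series, on what has been measured and on what is new or still open speak of the compounds shown alone.

In an ADME assay on L929 cells (Mus musculus) for cytotoxicity, read by resazurin assay, with a stated time of 48 h (a lower number here means that less compound is tolerated, a higher number that more compound is tolerated), compound 1 `C#CCn1c2ccc([N+](=O)[O-])cc2c(=O)n1Cc1ccccc1` gives 195000 nM and compound 2 `O=c1c2cc([N+](=O)[O-])ccc2n(CCCBr)n1Cc1ccccc1` gives 25200 nM. Compound 3 `COC(=O)CCn1c2ccc([N+](=O)[O-])cc2c(=O)n1Cc1ccccc1` gives > 256000 nM, which is a limit of the assay and not a number. Its position is therefore known only as a floor. The comparison with the first chain shows an at least 1.3-fold higher number from compound 1 to compound 3 (0.11 log units; that floor lies within the scatter). The comparison with the bromo chain shows an at least 10-fold higher number from compound 2 to compound 3 (1.00 log units; beyond the scatter).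

The next change is on a saturated chain carbon, two bonds along the chain from an aromatic nitrogen. Carbamoylmethyl in place of methoxycarbonyl there turns compound 3 into compound 4 `NC(=O)CCCn1c2ccc([N+](=O)[O-])cc2c(=O)n1Cc1ccccc1` (carbamoylmethyl in place of methoxycarbonyl on a saturated chain carbon, two bonds along the chain from an aromatic nitrogen).

All three measured steps concern this same chain. The two that lie beyond the scatter both involve compound 2, the other being a 7.7-fold lower number from compound 1 to compound 2 (0.89 log units; beyond the scatter). Compound 4 carries no bromine, so those steps offer little guide to it. The closer guide is the pair without bromine, where the change in this assay stays within the scatter as an at least 1.3-fold higher number from compound 1 to compound 3 (0.11 log units; that floor lies within the scatter). No step beyond the scatter is therefore expected, and the estimated step is an at least 1.1-fold lower number from compound 3 to compound 4 (0.06 log units; that floor lies within the scatter). The estimate for compound 4 is 220000 nM, with an expected range of 90000 nM to 500000 nM.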

Compound 4, concentration lethal to 50% of the cells: > 256000 nM
Compound 4: a limit, no number (the forecaster's own chance of this, stated with the estimate: 45%); middle value at least 1.1-fold (0.06 log units) from the limit.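

In this assay compound 4 gives > 256000 nM, which is a limit of the assay and not a number, and it shares that ceiling with compound 3: the limit of > 256000 nM in this assay, at which 2 of the 4 values shown sit. The step from methoxycarbonyl to carbamoylmethyl, on a saturated chain carbon, two bonds along the chain from an aromatic nitrogen, cannot be read, so no size can be given for this change. The series does gain a further chain without bromine, here carrying a hydrogen-bond donor, and the comparison with the bromo chain gives an at least 10-fold higher number from compound 2 to compound 4 (1.00 log units; beyond the scatter), whereas the comparison with the ethynyl chain gives an at least 1.3-fold higher number from compound 1 to compound 4 (0.11 log units; that floor lies within the scatter).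

On these data alone, whether the ester and amide chains differ at all remains open, since neither has a number in this assay. Also open, as far as these compounds go, is where a carboxylic acid or a primary amine at the end of this chain, or a longer chain carrying the same amide, would fall in this assay.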